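Amides of One Acid: Estimating a Thiomorpholine Amide

A few compounds are considered here, and "the series" means these few. Any claim that something is new, unique, unknown or untested is made for them only; others in the source may bear on it.

Measured compounds:
- compound 1, `CCCCc1nc(C)c(CC(=O)O)c(=O)n1Cc1ccc(-c2ccccc2-c2nnn[nH]2)cc1`: in an in vivo functional assay on the whole organism for inhibition, with Rattus norvegicus as the target (a lower number here means that less compound is needed, a higher number that more compound is needed for the effect), compound 1 gives 0.13 mg/kg
- compound 2, `CCCCc1nc(C)c(CC(=O)N(CC)CC)c(=O)n1Cc1ccc(-c2ccccc2-c2nnn[nH]2)cc1`: compound 2 gives 0.089 mg/kg
- compound 3, `CCCCc1nc(C)c(CC(=O)N2CCC[C@H]2C(N)=O)c(=O)n1Cc1ccc(-c2ccccc2-c2nnn[nH]2)cc1`: compound 3 gives 0.023 mg/kg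

Compound 1 shows the highest number of the three, so it needs the most compound; compound 2 is closest, and compound 3 sits furthest away. Compound 4, `CCCCc1nc(C)c(CCC(=O)N2CCSCC2)c(=O)n1Cc1ccc(-c2ccccc2-c2nnn[nH]2)cc1`, has not been measured. Compared with compound 1 the change is ((thiomorpholin-4-yl)carbonyl)methyl in place of carboxy on a saturated chain carbon bound to an aromatic carbon; the same difference, cut one bond further out, reads carboxymethyl to 2-((thiomorpholin-4-yl)carbonyl)ethyl. The two measured steps that speak to this both replace the hydroxy on the carbonyl carbon with an amine: a 1.5-fold lower number from compound 1 to compound 2 (0.16 log units; within the scatter) and a 5.7-fold lower number from compound 1 to compound 3 (0.75 log units; beyond the scatter). Both lower the number, one within the scatter and one beyond it. Among the measured compounds shown here, no measured pair tests the longer chain. A modest lowering is therefore expected, a 2.2-fold lower number from compound 1 to compound 4 (0.34 log units; beyond the scatter), with a wide range. Compound 4 is estimated at 0.06 mg/kg, between 0.02 mg/kg and 0.2 mg/kg.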

Compound 4, dose for half-maximal effect: 0.204 mg/kg
Beside the measured number, compound 4's estimate is 3.4-fold (0.53 log units) below it, and the stated range ends below it.
By their numbers in this assay, from the lowest: compound 3; then compounds 2, 1 and 4 (each within the scatter of the next, the first and the last beyond it).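

In this assay, the step from the carboxy group to ((thiomorpholin-4-yl)carbonyl)methyl is a 1.6-fold higher number from compound 1 to compound 4 (0.20 log units; within the scatter), so this amide on its longer chain cannot be told apart from the acid. The other two amides do stand apart from it, with a 2.3-fold higher number from compound 2 to compound 4 (0.36 log units; beyond the scatter) and, larger still, an 8.9-fold higher number from compound 3 to compound 4 (0.95 log units; beyond the scatter), which shows that the amides at this position do not all give the same result. No measurement shown offers an explanation for these differences.

Still open, as far as these compounds go, is whether the thiomorpholine ring or the longer chain sets compound 4 apart from the other two amides: both differences arrive together in this one compound. A 2-carboxyethyl group, which is the carboxylic acid on the longer chain, or a thiomorpholine amide on the shorter chain would help separate the two.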